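Fluoro for trifluoromethyl on a shared amide-piperazine core

The source may report more compounds than this note shows. Statements on the series, on what has been measured and on what is new or still open speak of the compounds shown alone.

Measured compounds:
Compound 1 `O=C(CCN1C(=O)CSc2ccccc21)N1CCN(c2ccc([N+](=O)[O-])cc2)CC1` gives 5600 nM
Compound 2 `O=C(CCN1C(=O)CSc2ccccc21)N1CCN(c2ccc(C(F)(F)F)cc2)CC1` gives 1000 nM
Compound 3 `O=C(CCN1C(=O)CSc2ccccc21)N1CCC(Cc2ccccc2)CC1` gives 3800 nM

In a functional assay on MDA-MB-231 cells (Homo sapiens) for inhibition, read by sulforhodamine B assay, with a stated time of 48 h (a higher number here means a weaker inhibitor of growth, a lower number a stronger inhibitor of growth), compound 2 stands lowest of the three numbers shown, separated from both others by more than the usual scatter. Among the measured compounds shown here, the one single-change step measured, a 5.6-fold lower number from compound 1 to compound 2 (0.75 log units; beyond the scatter), shows that exchanging the group on that aromatic carbon moves the number by a modest but real amount. For the measured compounds named here, compound 3 carries a different ring in place of the aryl-piperazine, and no single-change step links it to compound 2; its value is simply higher.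

Compound 4 `O=C(CCN1C(=O)CSc2ccccc21)N1CCN(c2ccc(F)cc2)CC1` differs from compound 2 by fluoro in place of trifluoromethyl on an aromatic carbon. Going by the values given here, the only measured step that bears on this change is a 5.6-fold lower number from compound 1 to compound 2 (0.75 log units; beyond the scatter), since it too replaces the group on the same aromatic carbon. Given that nitro and trifluoromethyl already differ by a modest step, a change of similar size, but in the weaker direction, is expected for compound 4, an estimated 2.5-fold higher number from compound 2 to compound 4 (0.40 log units; beyond the scatter). Compound 4 is therefore expected to give about 2500 nM, in a range from 1000 nM to 6000 nM.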

Compound 4, concentration for 50% growth inhibition: 2200 nM
Compound 4: the middle estimate sits 1.1-fold (0.06 log units) above what was measured; measured number inside the range.
By their numbers in this assay, from the lowest: compound 2; then compounds 4, 3 and 1 (each within the scatter of the next, the first and the last beyond it).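

With compound 4 in this assay, this aromatic carbon now carries three groups whose effects can be compared directly on the shared core. Fluoro in place of trifluoromethyl gives a 2.2-fold higher number from compound 2 to compound 4 (0.34 log units; beyond the scatter), whereas fluoro in place of nitro gives a 2.5-fold lower number from compound 1 to compound 4 (0.41 log units; beyond the scatter), so fluoro falls between the other two groups, with every step beyond the scatter and trifluoromethyl giving the lowest number of the three. Nothing shown explains this order.

As far as these compounds go, what a methoxy group, an amine or a carboxylic acid would give on this carbon remains open. Also open, from the compounds shown here alone, is whether the order of the three groups would hold on another core, a question compound 3 cannot answer since no single change links it to the others.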